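The source may hold more compounds than are shown below. What is called first, only, known or untested is meant among the compounds shown, and "the series" means these compounds.

Measured compounds in a functional assay on A-431 cells (Homo sapiens) for antiproliferative activity, read by MTT assay, with a stated time of 48 h; a higher number here means a weaker inhibitor, a lower number a stronger inhibitor:
compound 1 `C=CC(=O)Nc1cccc(Nc2nc(Nc3ccc(OCCn4ccnc4)cc3)ncc2Cl)c1` gives 1340 nM
compound 2 `C=CC(=O)Nc1cccc(Nc2nc(Nc3ccc(OCCn4ccnc4)cc3)ncc2F)c1` gives 2480 nM
compound 3 `C=CC(=O)Nc1cccc(Nc2nc(Nc3ccc(Cn4ccnc4)cc3)ncc2Cl)c1` gives 733 nM

Compound 3 has the lowest of the three numbers, but its gap to compound 1 is within the scatter; only compound 2 stands clearly higher. Compound 4 `C=CC(=O)Nc1cccc(Nc2nc(Nc3ccc(Cn4ccnc4)cc3)ncc2F)c1` is the unmeasured partner of compound 3: fluoro in place of chloro on an aromatic carbon. Among the measured compounds shown here, the one measured step of the same kind, a 1.9-fold higher number from compound 1 to compound 2 (0.27 log units; within the scatter), bears directly on it, whereas a 1.8-fold lower number from compound 1 to compound 3 (0.26 log units; within the scatter) concerns a different change. A step of similar size, toward a higher number and likely within the scatter, is therefore expected in this assay. Compound 4 is estimated at 1300 nM, with a range from 500 nM to 3500 nM. This estimate is expected to mean a step of a 1.8-fold higher number from compound 3 to compound 4 (0.25 log units; within the scatter).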

Compound 4, half-maximal inhibitory concentration: 152 nM
For compound 4 the middle estimate is 8.6-fold (0.93 log units) above the measured one; the whole stated range lies above it.
By their numbers in this assay, from the lowest: compound 4; then compounds 3, 1 and 2 (each within the scatter of the next, the first and the last beyond it).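

In this assay, fluoro in place of chloro on this aromatic carbon gives a 4.8-fold lower number from compound 3 to compound 4 (0.68 log units; beyond the scatter), so with (1H-imidazol-1-yl)methyl on the shared core the change has a clear effect, and its size depends on the group it is paired with: the same change on two cores in this assay, a 1.9-fold higher number (0.27 log units; within the scatter) from compound 1 to compound 2 and a 4.8-fold lower number (0.68 log units; beyond the scatter) from compound 3 to compound 4, 8.9-fold (0.95 log units) apart, beyond the scatter of two such steps. The change of chain likewise depends on the halogen present, giving a 16-fold lower number from compound 2 to compound 4 (1.21 log units; beyond the scatter): the same change on two cores in this assay, a 1.8-fold lower number (0.26 log units; within the scatter) from compound 1 to compound 3 and a 16-fold lower number (1.21 log units; beyond the scatter) from compound 2 to compound 4, 8.9-fold (0.95 log units) apart, beyond the scatter of two such steps. The two changes therefore do not act independently in these compounds.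

Going by these compounds, how bromo or a nitrile would behave at this position remains open. So does whether a longer chain, such as 3-(1H-imidazol-1-yl)propyl, would keep the gain seen with fluoro.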